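This account rests on a few compounds, and the source may have more. Where it says the series, first, only, none or still open, it means among the compounds named here.

Going by the values given here, in a functional assay on NCI-H226 cells (Homo sapiens) for inhibition, read by sulforhodamine B assay, with a stated time of 48 h, tested at 10 uM (on this read-out higher numbers stand for more inhibition of growth at the one concentration tested and lower numbers for less inhibition of growth), compound 1 (`COc1ccc(-c2nc3sc(-c4ccccc4)cn3n2)cc1`) gives 23% and stands highest of the three numbers so far. Compound 2 (`C/C(=N/O)c1ccc(NC(=O)Cn2nc(C(F)(F)F)nc2N)cc1`) gives 12.9% and compound 3 (`C/C(=N/O)c1ccc(NC(=O)Cn2nc(-c3ccccc3)nc2N)cc1`) gives 3.91% and both lie beyond the usual scatter under compound 1. The next compound to be tested is compound 4 (`COc1ccc(-c2nc3sc(-c4ccc(Cl)cc4)cn3n2)cc1`). It keeps the core of compound 1 and changes one thing: chloro in place of hydrogen on an aromatic carbon, para to a large group, so that phenyl becomes 4-chlorophenyl (chloro in place of hydrogen on an aromatic carbon). Among the compounds with values here, no measured pair shows this change. Within the data shown here, the one measured step, a number 9 percentage points lower from compound 2 to compound 3 (within the scatter), stays within the scatter and concerns another group on another core, so it is only a weak guide. With so little to go on, no step beyond the scatter is expected in this assay and the data favour no clear direction. The estimated step of a number 2 percentage points higher from compound 1 to compound 4 (within the scatter) is therefore small and inside the scatter, though the uncertainty around it is wide. For compound 4 the estimated value is 25% with an expected range from 10% to 42% until the measurement is in.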

Compound 4, percent growth inhibition at one concentration: 49.9%
Estimate against measurement, compound 4: 24.9 percentage points below, and the stated range ends below it.
By their numbers in this assay, from the lowest: compounds 3 and 2 (each within the scatter of the next); then compound 1; then compound 4.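

In this assay, putting chloro in place of hydrogen on an aromatic carbon, para to a large group, gives a number 26.9 percentage points higher from compound 1 to compound 4 (beyond the scatter) and so turns phenyl into 4-chlorophenyl. This is the first step in the set that clears the scatter, whereas the only earlier step, a number 9 percentage points lower from compound 2 to compound 3 (within the scatter), stayed inside it and concerned a different group on a different core, so this position is the first place shown where one added heavy atom visibly moves growth inhibition at the single concentration tested. Nothing shown bears on the reason for this rise in the number.

This single pair cannot tell whether the gain belongs to chlorine itself or would also appear with another group at the same place, such as fluoro, methyl, methoxy or an amine. It also leaves open whether chloro would act alike on another carbon of this ring, and whether the rise at one concentration would carry over to a full concentration-response measurement on these cells.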